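This account rests on a few compounds, and the source may have more. Where it says the series, first, only, none or still open, it means among the compounds named here.

Of the compounds shown here, two have so far been tested in a functional assay on B16 cells (Mus musculus) for inhibition; on this read-out higher numbers stand for weaker inhibition and lower numbers for stronger inhibition. Compound 1 `NC(=S)N/N=C/c1cccc(O)c1` gives 24000 nM, while compound 2 `CCc1ccccc1/C=N/NC(N)=S` gives 2700 nM. Compound 2 therefore holds the lower of the two numbers, meaning the stronger inhibition, and the gap lies beyond the scatter. The next compound, compound 3 `COc1ccccc1/C=N/NC(N)=S`, is compound 2 with one change: methoxy in place of ethyl on an aromatic carbon, (methoxy in place of ethyl on an aromatic carbon). Within the data shown here, no measured pair shows a single change of this kind, so the data give no direct guide to its size. With compound 2 at 2700 nM as the starting point, a modest rise in the number is expected, perhaps not beyond the scatter. The expected change is a 1.5-fold higher number from compound 2 to compound 3 (0.17 log units; within the scatter). For compound 3 the estimated value is 4000 nM, within a range from 1200 nM to 14000 nM.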

Compound 3, half-maximal inhibitory concentration: 16100 nM
Beside the measured number, compound 3's estimate is 4.0-fold (0.60 log units) below it; the measured number lies above the stated range.
By their numbers in this assay, from the lowest: compound 2; then compounds 3 and 1 (each within the scatter of the next).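

In this assay, replacing ethyl with methoxy on this aromatic carbon, ortho to a group of 6 heavy atoms, gives a 6.0-fold higher number from compound 2 to compound 3 (0.78 log units; beyond the scatter). This position therefore responds to the swap, even though the two groups have the same count of heavy atoms, so that count alone does not set the number here. What differs by count is that one carbon gives way to an oxygen and one hydrogen-bond acceptor enters, but no measurement shown explains the rise.

Going by these compounds, whether a longer chain such as propyl, or an amine, on the same carbon would give a number nearer that of compound 2 remains open. On these data alone, it is also open whether the swap of ethyl for methoxy would have a step of similar size on another carbon of the ring.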